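Cyclising the side chain on the shared core

The compounds below may be only part of what the source reports. "The series", "measured", "known", "first", "only" and "open" are said of these compounds alone.

Measured so far:
compound 1 `Cn1cnc2c(NC(=N)N)nc(N)nc21`: > 100000 nM
compound 2 `CC[C@@H](CO)Nc1nc(NC(=N)N)c2ncn(C(C)C)c2n1`: 1600 nM

In a functional assay on MCF7 cells (Homo sapiens) for inhibition, read by fluorescence, with a stated time of 72 h (a lower number here means a stronger inhibitor, a higher number a weaker inhibitor), compound 1 gives only a limit, > 100000 nM; this sits at the limit of > 100000 nM in this assay, at which 1 of the 2 values shown sits. Among the compounds with values here, compound 2 gives 1600 nM in this assay, the only number among the values so far. Compound 3 `CC(C)n1cnc2c(NC(=N)N)nc(N3CCC[C@@H]3CO)nc21` is not yet measured; it differs from compound 2 by 2-(hydroxymethyl)pyrrolidin-1-yl in place of (1-(hydroxymethyl)propyl)amino on an aromatic carbon. Within the data shown here, no measured step of this kind exists to go by, so the step of a 1.9-fold higher number from compound 2 to compound 3 (0.27 log units; within the scatter) is expected to be modest, towards weaker inhibition, and may well fall within the scatter. Compound 3 is estimated at 3000 nM, with a range from 800 nM to 12000 nM.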

Compound 3, half-maximal inhibitory concentration: 20400 nM
Compound 3: the middle estimate sits 6.8-fold (0.83 log units) below what was measured, and the stated range ends below it.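

In this assay, tying the side chain into 2-(hydroxymethyl)pyrrolidin-1-yl on the aromatic carbon between two ring nitrogen atoms is far from a neutral swap: a 13-fold higher number from compound 2 to compound 3 (1.11 log units; beyond the scatter). Within the data shown here, as the only step available, it shows that this position responds strongly to replacing (1-(hydroxymethyl)propyl)amino with the ring. Nothing measured here points to a cause for this step.

From the compounds shown here alone, it remains open whether a piperidine ring or an open-chain dialkylamine carrying the same hydroxyl would read like compound 3 or compound 2.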